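A few compounds are considered here, and "the series" means these few. Any claim that something is new, unique, unknown or untested is made for them only; others in the source may bear on it.

Measured so far:
compound 1, `c1ccc2c(-c3cn4ccnc4c(-c4ccc5ncn(C6CCCCC6)c5c4)n3)cccc2c1`, 23%
compound 2, `CC(=O)c1ccc(-c2cn3ccnc3c(-c3ccc4ncn(C5CCCCC5)c4c3)n2)cc1`, 23.1%

In a functional assay on UO-31 cells (Homo sapiens) for inhibition, read by sulforhodamine B assay, with a stated time of 48 h, tested at 10 uM (on this read-out higher numbers stand for more inhibition at the one concentration tested (going by the name of the read-out) and lower numbers for less inhibition), compound 1 gives 23%, the lowest of the two numbers recorded; its nearest neighbour is compound 2, and the step of a number 0.1 percentage points higher from compound 1 to compound 2 (within the scatter) lies within the scatter, so the two compounds cannot be told apart on this read-out.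

Compound 3, `Brc1ccc(-c2cn3ccnc3c(-c3ccc4ncn(C5CCCCC5)c4c3)n2)cc1`, has not yet been measured. It differs from compound 1 in one place: 4-bromophenyl in place of naphthalen-1-yl on an aromatic carbon.

For the measured compounds named here, only one measured step speaks to such a change. From compound 1 to compound 2 the same naphthalen-1-yl was exchanged for 4-acetylphenyl on the same aromatic carbon, and a number 0.1 percentage points higher from compound 1 to compound 2 (within the scatter) shows no movement beyond the scatter. The exchange for 4-bromophenyl in compound 3 is a further change at that one place, with nothing in the recorded numbers that points in either direction, so no step beyond the scatter is expected in this assay.

Compound 3 is therefore estimated at 23%, with a range from 8% to 38%, which means an expected step of no change at the digits printed from compound 1 to compound 3 (within the scatter).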

Compound 3, a percentage reported as inhibition, at one concentration (the size of the read-out at that concentration, not a potency): 42.9%
For compound 3 the middle estimate is 19.9 percentage points below the measured one, outside the stated range (above it).
By their numbers in this assay, from the lowest: compounds 1 and 2 (each within the scatter of the next); then compound 3.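

The exchange of groups on this aromatic carbon, next to the ring nitrogen, is not without consequence in this assay: with 4-bromophenyl in place of naphthalen-1-yl, the read-out shows a number 19.9 percentage points higher from compound 1 to compound 3 (beyond the scatter), a modest step that the earlier pair gave no sign of. The comparison of the two phenyl compounds, with bromo in place of acetyl, gives a number 19.8 percentage points higher from compound 2 to compound 3 (beyond the scatter), and compound 2 also carries a single phenyl ring, so losing the second ring of naphthalen-1-yl does not by itself go with the higher number; what sits on the phenyl ring makes the difference among these three compounds. Nothing available explains why bromo and acetyl part in this way.

Going by these compounds, it remains open whether the higher number is particular to bromo or would also appear with chloro, methoxy, an amine or a carboxylic acid on the same phenyl ring, or with an unsubstituted phenyl. These numbers also come from a single concentration in one cell line, so they leave the potency of compound 3 undefined.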